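The source may hold more compounds than are shown below. What is called first, only, known or untested is meant among the compounds shown, and "the series" means these compounds.

Values from a functional assay on HepG2 cells (Homo sapiens) for cytotoxicity, with a stated time of 72 h (on this read-out higher numbers stand for an effect only at larger amounts of compound and lower numbers for an effect already at smaller amounts), each one a limit of the assay and not a number:

- Compound 1 `C=C[C@@](C)(/C=C/c1ccc(Nc2ccc(Cl)c(F)c2)cc1)CCC=C(C)C`: > 52000 nM
- Compound 2 `C=C[C@@](C)(/C=C/c1ccc(-c2ccccc2)cc1)CCC=C(C)C`: > 52000 nM

Compound 2 gives only a limit, > 52000 nM. Both measured compounds share this position: the limit of > 52000 nM in this assay, at which 2 of the 2 values shown sit.

Compound 3 `C=C[C@@](C)(/C=C/c1ccc(-c2ccc(F)cc2)cc1)CCC=C(C)C` differs from compound 2 by one change: fluoro in place of hydrogen on an aromatic carbon. This is fluoro in place of hydrogen on an aromatic carbon, para to a large group, or phenyl to 4-fluorophenyl when cut one bond further out.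

For the measured compounds named here, the only measured step that bears on it is a step that the two limits leave unreadable from compound 1 to compound 2. That step involves a different exchange and has no readable size, so it offers no basis for expecting a shift in this assay. The expected step of a number no higher from compound 2 to compound 3 (the limit leaves the size open) is none beyond the scatter. Compound 3 is expected at 52000 nM, with an estimated range of 25000 nM to 100000 nM, and a further report as a limit is likely.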

Compound 3, half-maximal effective concentration: > 52000 nM
Compound 3: no number, only a limit; the forecaster's own chance of this, stated with the estimate: 85%; the middle value sits exactly at the limit.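

In this assay compound 3 gives > 52000 nM, a limit of the assay and not a number. Its steps from compound 1 and from compound 2 cannot be read. Left open is whether fluoro in place of hydrogen on an aromatic carbon shifts the true value in this assay at all.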